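Changing the Aryl Group on a Ring Nitrogen

A few compounds are considered here, and "the series" means these few. Any claim that something is new, unique, unknown or untested is made for them only; others in the source may bear on it.

In a functional assay on HL-60 cells (Homo sapiens) for inhibition, read by MTT assay, with a stated time of 72 h, tested at 30 uM (on this read-out higher numbers stand for more inhibition of growth at the one concentration tested and lower numbers for less inhibition of growth), compound 1 `C=CCc1ccc(OCc2cn(-c3ccccc3CO)nn2)c(O)c1` gives 31.7%. Compound 2 `C=CCc1cc(O)c(O)c(CN2CCC(CCO)CC2)c1` gives 39.4% in this assay, and the two numbers lie within the usual scatter of each other, so neither stands apart. Compound 3 `C=CCc1ccc(OCc2cn(-c3ccc(OC)cc3)nn2)c(O)c1` has not yet been measured. It differs from compound 1 by 4-methoxyphenyl in place of 2-(hydroxymethyl)phenyl on an aromatic nitrogen. For the measured compounds named here, no measured pair shows the effect of such a change, so its size cannot be read from the data. The step of a number 1.3 percentage points higher from compound 1 to compound 3 (within the scatter) is expected to be small, likely none beyond the scatter. Compound 3 is therefore expected to give 33% in this assay, within 15% to 55%.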

Compound 3, percent growth inhibition at one concentration: 21.3%
Compound 3: middle estimate off by 11.7 percentage points, on the high side, within the range that was stated.
By their numbers in this assay, from the lowest: compound 3; then compounds 1 and 2 (each within the scatter of the next).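

Putting 4-methoxyphenyl in place of 2-(hydroxymethyl)phenyl on the aromatic nitrogen gives a number 10.4 percentage points lower from compound 1 to compound 3 (beyond the scatter) in this assay. For the compounds shown here, this is the first step that shows this position responding to a change: the two groups hold the same atoms, joined differently, yet the read-out moves. No measurement on hand explains the step.

The compounds shown leave open whether the step follows the loss of the hydroxymethyl group or the arrival of the methoxy group. They also leave open how an unsubstituted phenyl or a 4-aminophenyl group would read on this nitrogen.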